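The compounds below may be only part of what the source reports. "The series", "measured", "known", "first", "only" and "open" are said of these compounds alone.

Of the compounds shown here, two have numbers so far in an ADME assay on MT4 cells (Homo sapiens) for cytotoxicity, read by MTT assay, with a stated time of 4 days; on this read-out higher numbers stand for lower toxicity in this test and lower numbers for higher toxicity in this test. Compound 1 (`COc1c(-c2ccc(F)cc2)oc2ccc(NC(C)=O)cc2c1=O`) gives 317000 nM and compound 2 (`COc1c(-c2ccccc2F)oc2ccc(N)cc2c1=O`) gives 234000 nM, so compound 2 stands within the scatter of compound 1 and the two cannot be ranked. The change from compound 2 to compound 3 (`COc1c(-c2ccc(F)cc2)oc2ccc(N)cc2c1=O`) is 4-fluorophenyl in place of 2-fluorophenyl on an aromatic carbon, next to the ring oxygen and ortho to a methoxy group (4-fluorophenyl in place of 2-fluorophenyl on an aromatic carbon). Among the compounds with values here, no measured pair isolates this change. Compound 1 also bears 4-fluorophenyl and gives 317000 nM in this assay, with no gap beyond the scatter from compound 2, so no step beyond the scatter is expected in either direction. The estimated step is a 1.1-fold higher number from compound 2 to compound 3 (0.05 log units; within the scatter), which stays within the scatter. For compound 3 the expected value is 260000 nM, with an estimated range of 130000 nM to 500000 nM.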

Compound 3, half-maximal cytotoxic concentration: 141000 nM
The estimate for compound 3 lay 1.8-fold (0.27 log units) above the measured number, and the stated range covers the measured number.
By their numbers in this assay, from the lowest: compounds 3, 2 and 1 (each within the scatter of the next, the first and the last beyond it).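

In this assay, within the data shown here, the first matched pair for this position, next to the ring oxygen, gives a 1.7-fold lower number from compound 2 to compound 3 (0.22 log units; within the scatter), so moving the fluorine from 2-fluorophenyl to 4-fluorophenyl does not separate the two compounds. The step beyond the scatter lies instead at the nitrogen on the aromatic ring: with 4-fluorophenyl held constant, hydrogen in place of acetyl gives a 2.2-fold lower number from compound 1 to compound 3 (0.35 log units; beyond the scatter), a modest change. Nothing available on these compounds explains either step.

As far as these compounds go, it remains open whether the acetyl step also holds with 2-fluorophenyl in place, and whether a longer acyl chain or a methanesulfonyl group on that nitrogen would follow it. Plain phenyl or chlorophenyl at the aryl position would show whether that site stays equally flat beyond the two fluorophenyl groups.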